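The source may report more compounds than this note shows. Statements on the series, on what has been measured and on what is new or still open speak of the compounds shown alone.

Working notes on the series. Compound 1 `O=C(COc1cccc2ccccc12)N/N=C/c1ccccc1Br` is the reference point for the step considered here. In an ADME assay on HEL cells (Homo sapiens) for cytotoxicity (on this read-out lower numbers stand for higher toxicity in this test and higher numbers for lower toxicity in this test), compound 1 gives only a limit of the assay, >= 20 ug/mL. Compound 2 `COc1ccc(/C=N/NC(=O)COc2cccc3ccccc23)cc1OC` likewise returns a limit in this assay, namely >= 20 ug/mL. Going by the values given here, compound 3 `C/C(=N\NC(=O)COc1cccc2ccccc12)c1ccccc1O` is the one member with a number rather than a limit: in this assay compound 3 gives 20 ug/mL. The picture across the three is uniform, with the values gathered at the limit of >= 20 ug/mL in this assay, at which 2 of the 3 values shown sit, so nothing in the measured set separates one analogue of the shared core from another.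

Compound 4 `O=C(COc1cccc2ccccc12)N/N=C/c1ccccc1O` has not yet been measured in this assay. Against compound 1 the change is hydroxy in place of bromo on an aromatic carbon; cut one bond further out it reads 2-bromophenyl to 2-hydroxyphenyl. Among the compounds with values here, no pair of measured compounds differs in exactly one place, so the size of any single change cannot be read off the measured set.

The step expected from compound 1 to compound 4 in this assay is a number no higher from compound 1 to compound 4 (the limit leaves the size open), that is, none beyond the scatter, because the measured compounds all rest at the limit of >= 20 ug/mL in this assay, at which 2 of the 3 values shown sit. For compound 4 the estimate in this assay is 20 ug/mL, expected to fall between 10 ug/mL and 40 ug/mL, and most likely to be returned as a limit again.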

Compound 4, minimum cytotoxic concentration: 20 ug/mL
Estimate against measurement, compound 4: no gap at the digits printed; measured number inside the range.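

At this place, on an aromatic carbon of a six-membered aromatic ring of carbon only and ortho to a large group, the change from bromo to hydroxy gives the series its first comparison in one place, and in this assay it reads as a number no higher from compound 1 to compound 4 (the limit leaves the size open). Compound 1 gives only a limit, >= 20 ug/mL, so the bromo end of the step stays unfixed and the size of the step cannot be read. Compound 4 gives a number, 20 ug/mL, which fixes the 2-hydroxyphenyl end of the step, and adding a hydrogen-bond donor and acceptor at this place leaves the series gathered at a single level: the limit of >= 20 ug/mL in this assay, at which 2 of the 4 values shown sit.

The compounds shown leave open whether bromo and hydroxy differ at all in this assay, and whether any group at this place, such as an amine or a carboxylic acid, would bring the read-out to a clearly lower number. Going by these compounds alone, they also leave open what a change in one place elsewhere on the shared core would do, as the only step available is this one.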